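Naphthyl to biphenyl on the sulfonamide of a dopamine ligand

A few compounds are considered here, and "the series" means these few. Any claim that something is new, unique, unknown or untested is made for them only; others in the source may bear on it.

Compound 1 `CCCN(CC[C@H]1CC[C@H](NC(=O)/C=C/c2cccc(F)c2)CC1)[C@H]1CCc2nc(N)sc2C1`: 9.9 nM
Compound 2 `CCCN(CC[C@H]1CC[C@H](NC(=O)c2ccc(-n3cncn3)cc2)CC1)[C@H]1CCc2nc(N)sc2C1`: 2.4 nM
Compound 3 `CCCN(CC[C@H]1CC[C@H](NS(=O)(=O)c2cccc3ccccc23)CC1)[C@H]1CCc2nc(N)sc2C1`: 1.5 nM

Of the compounds shown here, three sharing one core have been measured in an assay on brain for displacement of a labelled ligand from D(3) dopamine receptor (Rattus norvegicus); a lower number here means a stronger inhibitor, a higher number a weaker inhibitor. Compound 1 carries an amide built from a fluorinated styryl group, and in this assay compound 1 gives 9.9 nM. Compound 2 replaces that group, and the change from compound 1 to compound 2 gives a 4.1-fold lower number from compound 1 to compound 2 (0.62 log units; beyond the scatter). Compound 3 turns to a sulfonamide bearing a naphthalen-1-yl group; in this assay compound 3 gives 1.5 nM, a number within the scatter of that of compound 2 and, compared with compound 1, lower by more than the scatter.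

Compound 4 `CCCN(CC[C@H]1CC[C@H](NS(=O)(=O)c2ccc(-c3ccccc3)cc2)CC1)[C@H]1CCc2nc(N)sc2C1` is the next compound, not yet measured. It differs from compound 3 in one place: 4-phenylphenyl in place of naphthalen-1-yl on a sulfonyl sulfur. Among the compounds with values here, no measured step changes an aryl group on a sulfonyl sulfur, so the only bearing comes from the step from compound 1 to compound 2, where swapping one aromatic group for another on a carbonyl moved the number modestly. A step of similar or smaller size is expected here, with no firm direction. Compound 4 is therefore estimated to give 2.5 nM in this assay, between 0.8 nM and 8 nM, which would mean an expected step of a 1.7-fold higher number from compound 3 to compound 4 (0.22 log units; within the scatter).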

Compound 4, inhibition constant: 41 nM
The estimate for compound 4 lay 16-fold (1.21 log units) below the measured number, and the stated range ends below it.
By their numbers in this assay, from the lowest: compounds 3 and 2 (each within the scatter of the next); then compound 1; then compound 4.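

In this assay the aryl group on the sulfonyl sulfur proves far from interchangeable: 4-phenylphenyl in place of naphthalen-1-yl gives a 27-fold higher number from compound 3 to compound 4 (1.44 log units; beyond the scatter) as a large step, whereas the earlier swap on a carbonyl carbon gave only a 4.1-fold lower number from compound 1 to compound 2 (0.62 log units; beyond the scatter) as a modest one. The counted differences between the two groups are small, since both are made of carbon alone, both hold 2 six-membered aromatic rings of carbon only, neither carries a charge, and 4-phenylphenyl holds only slightly more heavy atoms, so a close match in these counts does not secure a close number at this position. Nothing available accounts for the size of this step.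

From the compounds shown here alone, it remains open whether the rise belongs to 4-phenylphenyl in particular or would also follow from a plain phenyl or a naphthalen-2-yl group on the sulfonyl sulfur. Also unresolved are whether 4-phenylphenyl on the carbonyl carbon of the amide would behave the same way, and whether an amine or a carboxylic acid on the 4-phenylphenyl group would change the number.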